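Adding a methyl to the ring amine of compound 2

The source may report more compounds than this note shows. Statements on the series, on what has been measured and on what is new or still open speak of the compounds shown alone.

Measured compounds:
compound 1, `CCCC/C=C/c1ccc(CO[C@@H]2CN[C@@H](CO)C2)cc1`, 5500 nM
compound 2, `CCCCCC/C=C/c1ccc(CO[C@@H]2CN[C@@H](CO)C2)cc1`, 1400 nM
compound 3, `CCCCCCCCCCCC/C=C/c1ccc(CO[C@@H]2CN[C@@H](CO)C2)cc1`, 5100 nM

In a functional assay on FL5.12 cells (Mus musculus) for cytotoxicity, read by flow cytometry, with a stated time of 48 h (a lower number here means a stronger inhibitor, a higher number a weaker inhibitor), compound 2 stands lowest of the three numbers. The step of a 3.9-fold lower number from compound 1 to compound 2 (0.59 log units; beyond the scatter) lies beyond the scatter, as does the step of a 3.6-fold higher number from compound 2 to compound 3 (0.56 log units; beyond the scatter), while the step of a 1.1-fold lower number from compound 1 to compound 3 (0.03 log units; within the scatter) lies within it. All three compounds share one core and differ only in the length of the alkyl chain.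

Compound 4, `CCCCCC/C=C/c1ccc(CO[C@H]2C[C@H](CO)N(C)C2)cc1`, differs from compound 2 by methyl in place of hydrogen on an amine nitrogen in a ring. For the measured compounds named here, none of the measured steps touches this amine nitrogen; they all concern the chain, so they give no direct guide to what a methyl on the ring amine does. Going by the values given here, with no step bearing on the change, the plain expectation is a number close to that of compound 2, with the uncertainty left open in both directions.

Compound 4 is therefore expected to give about 2000 nM in this assay, with a range from 600 nM to 7000 nM, which corresponds to an expected step of a 1.4-fold higher number from compound 2 to compound 4 (0.15 log units; within the scatter).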

Compound 4, half-maximal inhibitory concentration: 1900 nM
Compound 4: the middle estimate sits 1.1-fold (0.02 log units) above what was measured; the range from low to high includes it.
By their numbers in this assay, from the lowest: compounds 2 and 4 (each within the scatter of the next); then compounds 3 and 1 (each within the scatter of the next).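

In this assay, a methyl in place of hydrogen on the amine nitrogen in the ring gives a 1.4-fold higher number from compound 2 to compound 4 (0.13 log units; within the scatter), so the two compounds cannot be told apart by this measurement. For the compounds shown here, the earlier compounds showed only what the chain does, with steps such as a 3.9-fold lower number from compound 1 to compound 2 (0.59 log units; beyond the scatter) lying beyond the scatter; this pair is the first view of the ring amine, and it shows that, with this chain in place, the hydrogen on that nitrogen can be exchanged for a methyl while the number stays within the scatter. No supporting measurement accompanies this result, so nothing here explains it.

On these data alone, whether a larger group on this nitrogen, such as an ethyl or a benzyl, or an acetyl that would turn the amine into an amide, would also leave the number within the scatter remains open. Also open, as far as these compounds go, is whether the same methyl would give a similar step on the shorter chain of compound 1 or the longer chain of compound 3, since a single pair cannot describe this position in general.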